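Thiophene Attachment and Methylamino Swap on a Nucleoside Core

This account rests on a few compounds, and the source may have more. Where it says the series, first, only, none or still open, it means among the compounds named here.

Compound 2 `COc1ncnc2c1c(-c1cccs1)cn2[C@@H]1O[C@H](CO)[C@@H](O)[C@H]1O` and compound 1 `COc1ncnc2c1c(-c1ccsc1)cn2[C@@H]1O[C@H](CO)[C@@H](O)[C@H]1O` share a core and differ by thiophen-3-yl in place of thiophen-2-yl on an aromatic carbon. In a functional assay on CCRF-CEM cells (Homo sapiens), read by MTT assay, with a stated time of 72 h (a higher number here means a weaker inhibitor, a lower number a stronger inhibitor), compound 2 gives 90 nM, while compound 1 gives 2570 nM, a step of a 29-fold higher number from compound 2 to compound 1 (1.46 log units; beyond the scatter). Compound 3 `CNc1ncnc2c1c(-c1cccs1)cn2[C@@H]1O[C@H](CO)[C@@H](O)[C@H]1O` differs from compound 2 by methylamino in place of methoxy on an aromatic carbon. In this assay compound 3 reaches only a limit, > 20000 nM, one of the values sitting at the limit of > 20000 nM in this assay, at which 1 of the 3 values shown sits. That step is an at least 220-fold higher number from compound 2 to compound 3 (2.34 log units; beyond the scatter). Compound 4 `CNc1ncnc2c1c(-c1ccsc1)cn2[C@@H]1O[C@H](CO)[C@@H](O)[C@H]1O`, not yet measured, differs from compound 3 by thiophen-3-yl in place of thiophen-2-yl on an aromatic carbon, the same change as from compound 2 to compound 1. Because that change already produced a 29-fold higher number from compound 2 to compound 1 (1.46 log units; beyond the scatter), and compound 3 sits at the limit > 20000 nM, the expected step is a step that the limit leaves unreadable from compound 3 to compound 4. Compound 4 is therefore estimated at 60000 nM, most likely again reported only as a limit.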

Compound 4, half-maximal inhibitory concentration: > 20000 nM
Compound 4 was reported as a limit; the forecaster's own chance of this, stated with the estimate: 95%; the middle value is on the limit's open side.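

On the core of compound 1, methylamino in place of methoxy gives an at least 7.7-fold higher number from compound 1 to compound 4 (0.89 log units; beyond the scatter). The change therefore points the same way on both cores, but this does not show that it has the same size on each: the same change on two cores in this assay, an at least 220-fold higher number (2.34 log units; beyond the scatter) from compound 2 to compound 3 and an at least 7.7-fold higher number (0.89 log units; beyond the scatter) from compound 1 to compound 4; the limit leaves it open whether they differ

The thiophen-3-yl for thiophen-2-yl step between compound 3 and compound 4 cannot be read, since both compounds stand at a limit: the limit of > 20000 nM in this assay, at which 2 of the 4 values shown sit.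

The compounds shown leave open whether the thiophene position matters at all once methylamino is present. They also leave open how an ethoxy or a dimethylamino group in that place, or a furan-2-yl group in place of the thiophene, would read in this assay.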